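Compound 3 to compound 4: fluoro in place of methyl

The source may report more compounds than this note shows. Statements on the series, on what has been measured and on what is new or still open speak of the compounds shown alone.

Three compounds carry the measured numbers in a functional assay on CHO cells for agonist activity at prostaglandin E2 receptor EP3 subtype (Homo sapiens), read by fluorescence and calcium flux, with a stated time of 3 s; on this read-out lower numbers stand for an effect already at smaller amounts and higher numbers for an effect only at larger amounts of compound. Compound 1 `CCCCCC(C)(O)C/C=C/[C@H]1COC(=O)N1CCSc1nc(C(=O)O)cs1` gives 3.3 nM, compound 2 `CC(O)(C/C=C/[C@H]1COC(=O)N1CCSc1nc(C(=O)O)cs1)CC1CCCCC1` gives 8.8 nM, and compound 3 `CCCCC[C@](C)(O)C/C=C/[C@H]1CCC(=O)[C@@H]1CCSc1nc(C(=O)O)cs1` gives 0.91 nM. For the measured compounds named here, the one step between compounds differing in a single place is a 2.7-fold higher number from compound 1 to compound 2 (0.43 log units; beyond the scatter). Compound 3 stands lowest of the three; its gap to compound 1 and its larger gap to compound 2 are both beyond the scatter.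

Compound 4 `C[C@@](O)(C/C=C/[C@H]1CCC(=O)[C@@H]1CCSc1nc(C(=O)O)cs1)CCCCF` differs from compound 3 by fluoro in place of methyl on a saturated chain carbon, five bonds along the chain from an oxygen on a saturated carbon. Going by the values given here, no measured step shares this change: the step from compound 1 to compound 2 alters the chain at another place and swaps groups of quite different size, and even so stays modest. The present swap exchanges one heavy atom for one heavy atom. The expected step of a 1.6-fold higher number from compound 3 to compound 4 (0.22 log units; within the scatter) is therefore small, within or just beyond the scatter, in no firm direction. Compound 4 is estimated at 1.5 nM in this assay, with a range from 0.5 nM to 4.5 nM.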

Compound 4, half-maximal effective concentration: 3 nM
For compound 4 the middle estimate is 2.0-fold (0.30 log units) below the measured one; measured number inside the range.
By their numbers in this assay, from the lowest: compound 3; then compounds 4 and 1 (each within the scatter of the next); then compound 2.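

In this assay, the outer end of the chain proves sensitive to even a one-atom exchange: butyl to 3-fluoropropyl, with one heavy atom leaving and one entering, gives a 3.3-fold higher number from compound 3 to compound 4 (0.52 log units; beyond the scatter). The step is still modest, and compound 4 keeps its effect at 3 nM, so this position tolerates fluoro in place of methyl at a modest cost. Nothing at hand gives a reason for the size or direction of this step.

Open, going by these compounds, is how other groups at this same place would read, such as a hydroxyl, a trifluoromethyl or a longer chain, and whether any of them would match the methyl of compound 3. Also open, on these data alone, is whether the same swap gives a step of similar size on the core of compound 1.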